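Swapping the fluorophenyl of compound 2 for a thiophene

A few compounds are considered here, and "the series" means these few. Any claim that something is new, unique, unknown or untested is made for them only; others in the source may bear on it.

Measured compounds:
- compound 1, `COc1ccc(-c2cn3ccnc3c(-c3ccc4ncn(C5CCCCC5)c4c3)n2)cc1`: 80.9%
- compound 2, `Fc1ccc(-c2cn3ccnc3c(-c3ccc4ncn(C5CCCCC5)c4c3)n2)cc1`: 7.94%
- compound 3, `CC(=O)c1ccc(-c2cn3ccnc3c(-c3ccc4ncn(C5CCCCC5)c4c3)n2)cc1`: 3.02%

All three share one core and differ only in the group attached to it. In a functional assay on U-251 cells (Homo sapiens) for inhibition, read by sulforhodamine B assay, with a stated time of 48 h, tested at 10 uM (a lower number here means less inhibition, a higher number more inhibition at the concentration tested (going by the name of the read-out)), compound 1 gives 80.9%. Compound 2 stands second highest of the three numbers: compound 3 sits closest to it, with the step of a number 4.9 percentage points lower from compound 2 to compound 3 (within the scatter), while the step of a number 73 percentage points lower from compound 1 to compound 2 (beyond the scatter) marks the large gap to compound 1. The step of a number 77.9 percentage points lower from compound 1 to compound 3 (beyond the scatter) shows the same picture for compound 3.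

Compound 4, `c1csc(-c2cn3ccnc3c(-c3ccc4ncn(C5CCCCC5)c4c3)n2)c1`, has not yet been measured. Relative to compound 2 the change is thiophen-2-yl in place of 4-fluorophenyl on an aromatic carbon. Going by the values given here, no measured step replaces a whole ring with another ring, so none bears directly on this change; the nearest lesson is that, of the three groups tried, only the methoxy-bearing one of compound 1 gave strong inhibition, and both other groups gave little. On that basis the expected step of a number 7.1 percentage points higher from compound 2 to compound 4 (within the scatter) is small, staying near the low numbers of compound 2 and compound 3, though with wide uncertainty. Compound 4 is therefore estimated at 15%, within a range from 0% to 55%.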

Compound 4, a percentage reported as inhibition, at one concentration (the size of the read-out at that concentration, not a potency): 3.92%
Estimate against measurement, compound 4: 11.1 percentage points above; low and high end bracket the measured number.
By their numbers in this assay, from the lowest: compounds 3, 4 and 2 (each within the scatter of the next); then compound 1.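

In this assay a five-membered aromatic ring with sulfur at this position reads like the two low phenyl groups, with a number 4 percentage points lower from compound 2 to compound 4 (within the scatter) and a number 0.9 percentage points higher from compound 3 to compound 4 (within the scatter) as the two comparisons. The comparison with the high compound gives a number 77 percentage points lower from compound 1 to compound 4 (beyond the scatter) and so, among these four compounds, strong inhibition occurs only with 4-methoxyphenyl, and changing the ring itself does not restore it. No available measurement explains why compound 1 stands apart from the other three.

The compounds shown leave open whether this high inhibition depends specifically on the methoxy group, or whether an ethoxy group, a hydroxyl group or a dimethylamino group on the same phenyl ring would also give it. They also leave open whether a methoxy group carried on the thiophene would raise the low number of compound 4.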